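Swapping the Cyclohexyl Amide for an Isopropyl Urea

The source may hold more compounds than are shown below. What is called first, only, known or untested is meant among the compounds shown, and "the series" means these compounds.

compound 1, `COC(=O)/C=C/c1cccc(N(Cc2ccc(-c3c(OC)cccc3OC)cc2)C(=O)C2CCCCC2)c1`: 77 nM
compound 2, `COC(=O)/C=C/c1cccc(N(Cc2ccc(-c3cccc(C(C)=O)c3)cc2)C(=O)C2CCCCC2)c1`: 227 nM
compound 3, `COC(=O)/C=C/c1cccc(N(Cc2ccc(-c3ccc(OC(F)(F)F)cc3)cc2)C(=O)C2CCCCC2)c1`: 264 nM

In an assay on isolated protein with Bile acid receptor (Homo sapiens) as the target (a higher number here means that more compound is needed for the effect, a lower number that less compound is needed), compound 1 gives the lowest number of the three; the steps of a 2.9-fold higher number from compound 1 to compound 2 (0.47 log units; beyond the scatter) and a 3.4-fold higher number from compound 1 to compound 3 (0.54 log units; beyond the scatter) both go beyond the scatter, while a 1.2-fold higher number from compound 2 to compound 3 (0.07 log units; within the scatter) stays within it. Compound 4, `COC(=O)/C=C/c1cccc(N(Cc2ccc(-c3c(OC)cccc3OC)cc2)C(=O)NC(C)C)c1`, keeps the 2,6-dimethoxyphenyl side of compound 1 and changes the other end: isopropylamino in place of cyclohexyl on a carbonyl carbon. Among the compounds with values here, no measured step touches this carbonyl side; all three measured steps vary only the group on the aromatic carbon. The expectation for compound 4 therefore rests on compound 1 alone and carries wide uncertainty. A step of a 2.6-fold higher number from compound 1 to compound 4 (0.41 log units; beyond the scatter) is expected, toward a somewhat higher number. Compound 4 is estimated at 200 nM, within 50 nM to 800 nM.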

Compound 4, half-maximal effective concentration: 561 nM
Compound 4: the middle estimate sits 2.8-fold (0.45 log units) below what was measured; the range from low to high includes it.
By their numbers in this assay, from the lowest: compound 1; then compounds 2 and 3 (each within the scatter of the next); then compound 4.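

Within the data shown here, the carbonyl side, which no earlier compound varied, also affects the number in this assay: isopropylamino in place of cyclohexyl gives a 7.3-fold higher number from compound 1 to compound 4 (0.86 log units; beyond the scatter), so more compound is needed for the effect. This single swap removes the six-membered ring and brings in a nitrogen with one hydrogen-bond donor, and the step cannot separate these two changes. No measurement here explains the change.

Still open, as far as these compounds go, is how a cyclohexylamino group, keeping the ring with the nitrogen, or a plain isopropyl group, keeping the branched carbons without it, would compare with compound 1.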